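The source may report more compounds than this note shows. Statements on the series, on what has been measured and on what is new or still open speak of the compounds shown alone.

Values so far in a functional assay on MDA-MB-231 cells (Homo sapiens) for inhibition, with a stated time of 72 h (on this read-out lower numbers stand for stronger inhibition and higher numbers for weaker inhibition), are these:
- compound 1 `COc1ccc(NC(=O)Nc2nc(Sc3c[nH]c4ccccc34)cc(N3CCCCC3)n2)cc1` gives 7260 nM
- compound 2 `COc1ccc(NC(=O)Nc2nc(Sc3c[nH]c4ccccc34)cc(N3CCN(c4ccccn4)CC3)n2)cc1` gives 28400 nM
- compound 3 `COc1ccc(NC(=O)Nc2nc(Nc3cc(OC)cc(OC)c3)cc(Sc3c[nH]c4ccccc34)n2)cc1` gives 9460 nM

Compound 1 stands level with compound 3 (a 1.3-fold higher number from compound 1 to compound 3 (0.11 log units; within the scatter)), and compound 2 lies clearly higher (a 3.9-fold higher number from compound 1 to compound 2 (0.59 log units; beyond the scatter)). The next entry is compound 4 `O=C(Nc1ccccc1)Nc1nc(Sc2c[nH]c3ccccc23)cc(N2CCCCC2)n1`, which keeps the shared core and the piperidin-1-yl group of compound 1. Going by the values given here, its one change is hydrogen in place of methoxy on an aromatic carbon, para to a large group, so that 4-methoxyphenyl becomes phenyl (hydrogen in place of methoxy on an aromatic carbon).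

Among the compounds with values here, no measured step touches this place. All three measured steps exchange the piperidin-1-yl group or its replacements, so they serve only as a gauge of how far numbers move in this series. The remaining one is also modest (a 3.0-fold lower number from compound 2 to compound 3 (0.48 log units; beyond the scatter)). The data therefore give no direction for the loss of methoxy, and only a small movement is expected, with wide uncertainty on either side. The expected step is a 1.1-fold higher number from compound 1 to compound 4 (0.04 log units; within the scatter) and would lie within the scatter. Compound 4 is estimated at 8000 nM with an expected range from 3000 nM to 21000 nM in this series.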

Compound 4, half-maximal inhibitory concentration: 8130 nM
For compound 4 the middle estimate is 1.0-fold (0.01 log units) below the measured one; measured number inside the range.
By their numbers in this assay, from the lowest: compounds 1, 4 and 3 (each within the scatter of the next); then compound 2.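

In this assay, going by these compounds alone, this is the first reading at the far aryl end of the series, where the other steps all exchange the piperidin-1-yl group or its replacements: a 1.1-fold higher number from compound 1 to compound 4 (0.05 log units; within the scatter). With the piperidin-1-yl group held in place, methoxy on the aromatic carbon para to a large group can therefore give way to hydrogen with no change beyond the scatter, so the 4-methoxyphenyl and phenyl forms read alike in this pair. This single pair shows only that the methoxy is not needed to keep the number where it stands, and no measured property is available to explain that outcome.

Hydrogen and methoxy are the only two substituents shown at this position, so it remains open whether a different group there, such as a dimethylamino group, a carboxylic acid or a longer alkoxy chain, would move the number in either direction. On these data alone, it is also open whether the same exchange would read alike alongside the (3,5-dimethoxyphenyl)amino group of compound 3 or the 4-(pyridin-2-yl)piperazin-1-yl group of compound 2, both of which still carry the methoxy.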